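The source may report more compounds than this note shows. Statements on the series, on what has been measured and on what is new or still open speak of the compounds shown alone.

In a functional assay on MT4 cells (Homo sapiens) for cytotoxicity, read by MTT assay (on this read-out higher numbers stand for lower toxicity in this test and lower numbers for higher toxicity in this test), three compounds with a shared core have been measured. Compound 1 `Cc1c(O)nc(SCc2ccc(C#N)cc2)nc1Cc1c(Cl)cccc1Cl`, bearing cyano, gives > 60000 nM, which is a limit. Compound 2 `Cc1c(O)nc(SCc2ccccc2)nc1Cc1c(Cl)cccc1Cl`, bearing hydrogen at that place, gives > 64000 nM, also a limit. Among the measured compounds shown here, compound 3 `Cc1c(O)nc(SCc2ccc(Br)cc2)nc1Cc1c(Cl)cccc1Cl`, bearing bromo, gives 13000 nM, the only true number of the three. Compound 4 `CCOc1ccc(CSc2nc(O)c(C)c(Cc3c(Cl)cccc3Cl)n2)cc1` differs from it by ethoxy in place of bromo on an aromatic carbon. For the measured compounds named here, two measured steps bear on this change, an at least 4.9-fold lower number from compound 2 to compound 3 (0.69 log units; beyond the scatter) and an at least 4.6-fold lower number from compound 1 to compound 3 (0.66 log units; beyond the scatter). Both reach the bromo compound, so ethoxy, itself untested, is expected to give back a modest rise in this assay. The expected step is a 2.3-fold higher number from compound 3 to compound 4 (0.36 log units; beyond the scatter). For compound 4 the estimated value is 30000 nM, with an expected range of 10000 nM to 80000 nM.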

Compound 4, half-maximal cytotoxic concentration: > 58000 nM
Compound 4 was reported as a limit; the forecaster's own chance of this, stated with the estimate: 40%; middle value at least 1.9-fold (0.28 log units) from the limit.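

In this assay, ethoxy at this position gives an at least 4.4-fold higher number from compound 3 to compound 4 (0.64 log units; beyond the scatter), so the lower number seen with bromo does not carry over to this group of more heavy atoms. Bromo in compound 3 now stands alone among the four groups in giving a true number, while compound 1, compound 2 and compound 4 all end at limits. The steps from compound 1 and compound 2 to compound 4 each join two limits and cannot be read.

From the compounds shown here alone, how far those three compounds lie past their limits stays open. So does whether chloro, iodo or an amine here would behave like bromo or like ethoxy.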